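The source may hold more compounds than are shown below. What is called first, only, known or untested is meant among the compounds shown, and "the series" means these compounds.

Compound 1, `COc1ccc(NC(=O)COc2c(-c3ccccc3)oc3ccccc3c2=O)cc1`, in a functional assay on MT2 cells (Homo sapiens) for antiproliferative activity, read by MTT assay, with a stated time of 72 h (a higher number here means a weaker inhibitor of growth, a lower number a stronger inhibitor of growth), gives a result that is a limit of the assay and not a number: > 10000 nM. Compound 2, `O=C(COc1c(-c2ccccc2)oc2ccccc2c1=O)Nc1ccc(-c2ccccc2)cc1`, in this assay also gives only a limit of the assay: > 10000 nM. Going by the values given here, compound 3, `COc1ccc(NC(=O)COc2ccc3oc(-c4ccccc4)cc(=O)c3c2)cc1`, is the one compound here with an actual number in this assay: 3010 nM.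

Compound 1 and compound 2 share one core and differ in a single place, (phenyl in place of methoxy on an aromatic carbon). The step between them, a step that the two limits leave unreadable from compound 1 to compound 2, cannot be read in size, because the limit of > 10000 nM in this assay, at which 2 of the 3 values shown sit, is where both of their results sit.

Compound 3 is built from the same atoms as compound 1, joined differently; the difference between the two cores is not broken down here. On the core of compound 3 the same change is now made, giving compound 4, `O=C(COc1ccc2oc(-c3ccccc3)cc(=O)c2c1)Nc1ccc(-c2ccccc2)cc1`, which has not yet been measured in this assay. The change is phenyl in place of methoxy on an aromatic carbon, and the place it occurs is described in the same words as for the pair of compound 1 and compound 2, so it is the same change, not merely the same kind.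

Because the step that the two limits leave unreadable from compound 1 to compound 2 is unreadable, it gives no guidance on direction or size. The expectation for compound 4 therefore rests mainly on the number of compound 3, 3010 nM, with wide uncertainty. The step from compound 3 to compound 4 is expected to be about a 1.0-fold lower number from compound 3 to compound 4 (0.00 log units; within the scatter). Compound 4 is thus estimated at 3000 nM, with a plausible range from 1000 nM to 10000 nM, and a real chance that only a limit is reported.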

Compound 4, concentration for 50% growth inhibition: > 10000 nM
Compound 4: a limit, no number; the forecaster's own chance of this, stated with the estimate: 35%; at least 3.3-fold (0.52 log units) between middle value and limit.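

In this assay, phenyl in place of methoxy on an aromatic carbon gives an at least 3.3-fold higher number from compound 3 to compound 4 (0.52 log units; beyond the scatter), a loss of growth inhibition on this core that is real, although its size is only a minimum. As far as these compounds go, compound 4 gives > 10000 nM, which is a limit of the assay and not a number, so how much weaker it is than its methoxy partner remains unknown. Going by these compounds alone, the matching step between compound 1 and compound 2 cannot be read, so nothing here shows whether the change acts the same way on both cores, since those results and the one for compound 4 all stop at one ceiling: the limit of > 10000 nM in this assay, at which 3 of the 4 values shown sit.

The compounds shown leave open whether another group at this place, such as an amine, a carboxylic acid or a longer alkoxy chain, would keep or improve on the growth inhibition of compound 3, at 3010 nM. They also leave open how weak compound 1, compound 2 and compound 4 really are, as none of the three has an actual number in this assay.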